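Adding fluoro to compound 3: a series of limits

The source may hold more compounds than are shown below. What is called first, only, known or untested is meant among the compounds shown, and "the series" means these compounds.

Of the compounds shown here, three on the shared core have been read so far in an ADME assay on THP-1 cells (Homo sapiens) for cytotoxicity, read by flow cytometry and propidium iodide staining, with a stated time of 72 h (a lower number here means a stronger inhibitor, a higher number a weaker inhibitor), and none of them gives a number. Compound 1 `Cn1cnc(CS(=O)(=O)c2ccc(F)cc2)c1[N+](=O)[O-]`, which already carries 4-fluorophenyl, gives > 835000 nM as a limit of the assay. Compound 2 `Cc1nc(CS(=O)(=O)c2ccccc2)c([N+](=O)[O-])n1C` gives > 846000 nM as a limit of the assay. Compound 3 `Cc1nc(CS(=O)(=O)c2ccccc2)c([N+](=O)[O-])n1CCO` gives > 768000 nM as a limit of the assay. Compound 3 therefore stands with the other two values, and no order can be read among them.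

Compound 4 `Cc1nc(CS(=O)(=O)c2ccc(F)cc2)c([N+](=O)[O-])n1CCO` comes from compound 3 by fluoro in place of hydrogen on an aromatic carbon, para to a large group (fluoro in place of hydrogen on an aromatic carbon), so that phenyl becomes 4-fluorophenyl. Among the compounds with values here, the only measured step is a step that the two limits leave unreadable from compound 2 to compound 3 and it lies at a different place in the structure. Within the data shown here, no measured step covers the fluoro change, and no size can be carried over. Among the measured compounds shown here, compound 1 is the one measured compound with 4-fluorophenyl, and it offers only a limit.

No shift beyond the scatter and no direction are expected, so the estimated step of an at least 1.0-fold lower number from compound 3 to compound 4 (0.02 log units; that floor lies within the scatter) is nominal. For compound 4 the estimate is 730000 nM with an expected range from 400000 nM to 1000000 nM and most likely only a limit will be reported.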

Compound 4, half-maximal inhibitory concentration: > 728000 nM
Compound 4: a limit, no number (the forecaster's own chance of this, stated with the estimate: 85%); the middle value is on the limit's open side.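

In this assay compound 3 and compound 4 both give only limits, so no step can be read between them. The compounds shown leave open whether fluoro in place of hydrogen on an aromatic carbon shifts this read-out at all, and at what concentration any compound on the shared core would give a number.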